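This account rests on a few compounds, and the source may have more. Where it says the series, first, only, none or still open, it means among the compounds named here.

For the measured compounds named here, in a functional assay on MCF7 cells (Homo sapiens) for antiproliferative activity, read by MTT assay, with a stated time of 24 h (on this read-out higher numbers stand for weaker inhibition and lower numbers for stronger inhibition), compound 3 `Cc1cc(OCc2nnc(SCc3cccc(F)c3)o2)cc2oc(=O)cc(C)c12` gives 26000 nM, the only number among the three values measured. Compound 1 `CCCSc1nnc(COc2cc(C)c3c(C)cc(=O)oc3c2)o1` gives only a limit, > 100000 nM. Compound 2 `CCCCCCSc1nnc(COc2cc(C)c3c(C)cc(=O)oc3c2)o1` likewise gives only a limit, > 100000 nM. Two of the three values thus sit at the limit of > 100000 nM in this assay, at which 2 of the 3 values shown sit. The steps of an at least 3.8-fold lower number from compound 1 to compound 3 (0.58 log units; beyond the scatter) and an at least 3.8-fold lower number from compound 2 to compound 3 (0.58 log units; beyond the scatter) show that a 3-fluorophenyl on a saturated chain carbon bound to a sulfur gives a lower number than ethyl or pentyl there. Compound 4 `Cc1cc(OCc2nnc(SCc3ccc(Cl)cc3Cl)o2)cc2oc(=O)cc(C)c12` differs from compound 3 by 2,4-dichlorophenyl in place of 3-fluorophenyl on a saturated chain carbon bound to a sulfur. Going by the values given here, no measured step compares one aryl group with another, so the measured steps give no direction for this change. The expected step is therefore within the scatter, a 1.2-fold lower number from compound 3 to compound 4 (0.07 log units; within the scatter). Compound 4 is estimated at 22000 nM, between 8000 nM and 70000 nM.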

Compound 4, half-maximal inhibitory concentration: < 5000 nM
Compound 4 ended at the assay's limit; the forecaster's own chance of this, stated with the estimate: 15%; at least 4.4-fold (0.64 log units) between middle value and limit.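

At this position, on a saturated chain carbon bound to a sulfur, the choice of aryl group matters, shown by an at least 5.2-fold lower number from compound 3 to compound 4 (0.71 log units; beyond the scatter). The gap to the plain alkyl chains also widens, with an at least 20-fold lower number from compound 2 to compound 4 (1.30 log units; beyond the scatter) and an at least 20-fold lower number from compound 1 to compound 4 (1.30 log units; beyond the scatter). All three steps give only a minimum size, since the value of compound 4 is itself a limit: the limit of < 5000 nM in this assay, at which 1 of the 4 values shown sits.

Going by these compounds, it remains open whether both chlorines are needed, which a phenyl carrying a single chlorine would test. On these data alone, how a pyridine ring or an amine would fare at this place also remains open.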